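Aryl ether variation in the shared core series

The compounds below may be only part of what the source reports. "The series", "measured", "known", "first", "only" and "open" are said of these compounds alone.

Compound 1 `O=C(O)C[C@@H]1C[C@H](C(F)(F)F)CN1c1ccc(Oc2ccccc2C(F)(F)F)cc1` gives 1300 nM in a functional assay on cells for agonist activity at Free fatty acid receptor 1 (Mus musculus), read by FLIPR and calcium flux, with a stated time of 100 s; on this read-out higher numbers stand for an effect only at larger amounts of compound and lower numbers for an effect already at smaller amounts; compound 2 `COc1ccc(Oc2ccc(N3C[C@@H](C(F)(F)F)C[C@H]3CC(=O)O)cc2)c(C)c1` gives 170 nM, and compound 3 `Cc1cccc(Oc2ccc(N3C[C@@H](C(F)(F)F)C[C@H]3CC(=O)O)cc2)c1C` gives 500 nM. Compound 3 sits second highest of the three numbers, between the others: a 2.6-fold lower number from compound 1 to compound 3 (0.41 log units; beyond the scatter), and a 2.9-fold higher number from compound 2 to compound 3 (0.47 log units; beyond the scatter). Compound 4 `Cc1c(Cl)cccc1Oc1ccc(N2C[C@@H](C(F)(F)F)C[C@H]2CC(=O)O)cc1` carries chloro in place of methyl on an aromatic carbon. Both measured steps swap the entire aryl group on the ether oxygen, and none exchanges a single methyl for chloro, so they bear only loosely on this step; each was modest yet beyond the scatter, so a change of similar or smaller size is plausible here. The step expected is a 1.3-fold lower number from compound 3 to compound 4 (0.10 log units; within the scatter), leaning toward a lower number. Compound 4 is estimated at 400 nM in this assay, with a range of 150 nM to 1100 nM.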

Compound 4, half-maximal effective concentration: 430 nM
The estimate for compound 4 lay 1.1-fold (0.03 log units) below the measured number, and the stated range covers the measured number.
By their numbers in this assay, from the lowest: compound 2; then compounds 4 and 3 (each within the scatter of the next); then compound 1.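

In this assay, chloro can take the place of methyl on this aromatic carbon, ortho to a methyl group, with no change beyond the scatter: a 1.2-fold lower number from compound 3 to compound 4 (0.07 log units; within the scatter). The 3-chloro-2-methylphenyl group therefore stays on the same side of the other two aryl groups as 2,3-dimethylphenyl, with a 2.5-fold higher number from compound 2 to compound 4 (0.40 log units; beyond the scatter) and a 3.0-fold lower number from compound 1 to compound 4 (0.48 log units; beyond the scatter). No measurement at hand accounts for these steps.

On these data alone, whether bromo or a nitrile on this carbon would match chloro and methyl remains open. Also open is what the methoxy of the 4-methoxy-2-methylphenyl group contributes in compound 2, as no compound shown differs from it in that one place.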